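A few compounds are considered here, and "the series" means these few. Any claim that something is new, unique, unknown or untested is made for them only; others in the source may bear on it.

Of the compounds shown here, two built on one shared core have been tested in a functional assay on HT-29 cells (Homo sapiens) for cytotoxicity, read by MTT assay, with a stated time of 72 h; a higher number here means a weaker inhibitor, a lower number a stronger inhibitor. Compound 1 `CN(C)CCn1cnnc1-c1cc(Oc2ccc(NC(=O)N/N=C/c3cc(C(C)(C)C)cc(C(C)(C)C)c3O)cc2F)ccn1` gives 680 nM. Compound 2 `COc1ccc(/C=N/NC(=O)Nc2ccc(Oc3ccnc(-c4nncn4CCN(C)C)c3)c(F)c2)c(OC)c1OC` gives 3970 nM, the higher of the two numbers, so compound 2 is the weaker inhibitor of the pair, and the gap between compound 1 and compound 2 lies beyond the scatter of repeated measurements.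

Compound 3 `COc1cc(/C=N/NC(=O)Nc2ccc(Oc3ccnc(-c4nncn4CCN(C)C)c3)c(F)c2)cc(OC)c1OC` has not yet been measured in this assay. It differs from compound 2 only in how the same atoms are joined: 3,4,5-trimethoxyphenyl in place of 2,3,4-trimethoxyphenyl on a carbon with a double bond to nitrogen. In plain terms, the methoxy groups are shifted around the aromatic ring that sits on the carbon with a double bond to nitrogen, while nothing is added or taken away. Within the data shown here, no measured pair differs in this way alone, so the data give no direct guide to the size of such a move. With nothing measured to set that size, no step beyond the scatter is expected in either direction. Compound 3 is therefore expected to give about 3000 nM in this assay, within a range from 1000 nM to 9000 nM. The step of a 1.3-fold lower number from compound 2 to compound 3 (0.12 log units; within the scatter) that this estimate implies is expected to stay within the scatter.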

Compound 3, half-maximal inhibitory concentration: 3620 nM
Compound 3: the middle estimate sits 1.2-fold (0.08 log units) below what was measured, and the stated range covers the measured number.
By their numbers in this assay, from the lowest: compound 1; then compounds 3 and 2 (each within the scatter of the next).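

In this assay, among these compounds, exchanging 2,3,4-trimethoxyphenyl for 3,4,5-trimethoxyphenyl on a carbon with a double bond to nitrogen gives a 1.1-fold lower number from compound 2 to compound 3 (0.04 log units; within the scatter) and offers the first direct reading of this kind of change. With the same atoms simply joined differently, these two methoxy patterns cannot be told apart in this cell test, so at this position the swap between them leaves the read-out within ordinary measurement noise. Nothing available here explains why the two patterns read alike.

Among the compounds shown here, this single pair says nothing about other arrangements, such as a ring carrying only one methoxy group or two, and it cannot show whether the same swap would behave alike on a different core. It also leaves open how a ring bearing an amine or a chlorine atom at this position would read, which would help show how much this part of the molecule can be altered before the cytotoxicity in this assay shifts beyond the scatter.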